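Ethyl to cyclopropyl on the amide nitrogen

The compounds below may be only part of what the source reports. "The series", "measured", "known", "first", "only" and "open" are said of these compounds alone.

Going by the values given here, in a functional assay on the whole organism with Mus musculus as the target, in the rotarod test (a higher number here means that more compound is needed for the effect, a lower number that less compound is needed), compound 1 `CCNC(=O)/C=C1\CCc2ccc(F)cc21` gives 136 mg/kg, the higher of the two numbers measured so far. Compound 2 `NC(=O)/C=C1\CCc2c1ccc(F)c2F` gives 50 mg/kg. The gap between these two values lies beyond the scatter. Compound 3 `O=C(/C=C1\CCc2ccc(F)cc21)NC1CC1` carries cyclopropyl in place of ethyl on an amide-type nitrogen. Among the compounds with values here, the series holds no measured step for a change at this place, so the expectation rests on the small size of the change alone. In this assay the expected step of a 1.2-fold lower number from compound 1 to compound 3 (0.09 log units; within the scatter) stays within the scatter, with no direction expected. For compound 3 the estimated value is 110 mg/kg, with an expected range of 45 mg/kg to 270 mg/kg.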

Compound 3, dose for half-maximal effect: 62 mg/kg
For compound 3 the middle estimate is 1.8-fold (0.25 log units) above the measured one; the range from low to high includes it.
By their numbers in this assay, from the lowest: compounds 2 and 3 (each within the scatter of the next); then compound 1.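

Going by these compounds alone, the amide nitrogen is the first place with a measured step: in this assay, cyclopropyl in place of ethyl gives a 2.2-fold lower number from compound 1 to compound 3 (0.34 log units; beyond the scatter), so a change of one carbon and one ring at this nitrogen can move the number beyond the scatter. This remains a modest step from a single pair, and nothing at hand explains it. Open, as far as these compounds go, is whether a larger ring such as cyclobutyl or a longer chain such as n-propyl on this nitrogen continues the direction. Also open, from the compounds shown here alone, is whether the same change holds on other cores.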